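Fluorine Position and Cytotoxicity in Two Related Cores

This account rests on a few compounds, and the source may have more. Where it says the series, first, only, none or still open, it means among the compounds named here.

Compound 1 `COc1ccc2[nH]c(-c3cccc(F)c3)cc(=O)c2c1O` was tested in a functional assay on Hep 3B2 cells (Homo sapiens) for cytotoxicity, read by MTT assay, with a stated time of 48 h (a lower number here means a stronger inhibitor, a higher number a weaker inhibitor), and gave 70 nM. Compound 2 `COc1ccc2[nH]c(-c3ccc(F)cc3)cc(=O)c2c1O` differs from compound 1 only in the change (4-fluorophenyl in place of 3-fluorophenyl on an aromatic carbon). In this assay compound 2 gave 11000 nM, so the step of a 160-fold higher number from compound 1 to compound 2 (2.20 log units; beyond the scatter) is large. Compound 3 `COc1cc2c(=O)cc(-c3cccc(F)c3)[nH]c2cc1O` carries the same 3-fluorophenyl on a different core; the difference between the two cores is not broken down here. In this assay compound 3 gave 5300 nM, a weaker result than compound 1. Compound 4 `COc1cc2c(=O)cc(-c3ccc(F)cc3)[nH]c2cc1O` is not yet measured; it differs from compound 3 by the same change, (4-fluorophenyl in place of 3-fluorophenyl on an aromatic carbon). Because the step of a 160-fold higher number from compound 1 to compound 2 (2.20 log units; beyond the scatter) was so large, a step of similar direction, a 7.5-fold higher number from compound 3 to compound 4 (0.88 log units; beyond the scatter), is expected for compound 4. Compound 4 is therefore estimated at 40000 nM, between 7000 nM and 250000 nM, with a real chance that this assay reports only a limit.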

Compound 4, half-maximal inhibitory concentration: > 100000 nM
Compound 4 ended at the assay's limit; the forecaster's own chance of this, stated with the estimate: 35%; middle value at least 2.5-fold (0.39 log units) away from the limit.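

On the second core, 4-fluorophenyl in place of 3-fluorophenyl again weakens the result in this assay, with an at least 18-fold higher number from compound 3 to compound 4 (1.27 log units; beyond the scatter). The value of compound 4, > 100000 nM, is a limit of the assay and not a number. The change therefore goes in the same direction on both cores, but this does not show whether its size carries over from one core to the other: the same change on two cores in this assay, a 160-fold higher number (2.20 log units; beyond the scatter) from compound 1 to compound 2 and an at least 18-fold higher number (1.27 log units; beyond the scatter) from compound 3 to compound 4; the limit leaves it open whether they differ

On these data alone, only 3-fluorophenyl and 4-fluorophenyl appear here, so it remains open how a phenyl ring carrying chlorine or an amine in place of fluorine would behave on either core. As far as these compounds go, it also remains open whether the same direction would hold on any further core.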